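The source may report more compounds than this note shows. Statements on the series, on what has been measured and on what is new or still open speak of the compounds shown alone.

Compound 1 `Cc1ccc(S(=O)(=O)NCCCNc2nccc(-c3c(-c4cccc(F)c4)nc4sccn34)n2)cc1` ends, two bonds along a short chain from a nitrogen on an aromatic ring, in a (((4-methylphenyl)sulfonyl)amino)methyl group. In a functional assay on SK-MEL-28 cells (Homo sapiens) for cytotoxicity, read by MTT assay (a lower number here means a stronger inhibitor, a higher number a weaker inhibitor), compound 1 gives 9500 nM, the second highest of three numbers. Compound 2 `O=C(NCCNc1nccc(-c2c(-c3cccc(F)c3)nc3sccn23)n1)c1ccc(Cl)cc1` gives 8160 nM, and compound 3 `O=S(=O)(NCCNc1nccc(-c2c(-c3cccc(F)c3)nc3sccn23)n1)c1ccc(Cl)cc1` gives 18600 nM. Both a 1.2-fold lower number from compound 1 to compound 2 (0.07 log units; within the scatter) and a 2.0-fold higher number from compound 1 to compound 3 (0.29 log units; within the scatter) stay within the scatter, while a 2.3-fold higher number from compound 2 to compound 3 (0.36 log units; beyond the scatter) counts as modest. Compound 4 `O=C(NCCNc1nccc(-c2c(-c3cccc(F)c3)nc3sccn23)n1)c1ccccc1` differs from compound 1 by benzamido in place of (((4-methylphenyl)sulfonyl)amino)methyl on a saturated chain carbon, two bonds along the chain from a nitrogen on an aromatic ring. The closest guide is compound 2, because a 1.2-fold lower number from compound 1 to compound 2 (0.07 log units; within the scatter) also swaps the sulfonyl group for a carbonyl one and differs from compound 4 only by a chlorine. The expected step is therefore small, a 1.1-fold lower number from compound 1 to compound 4 (0.02 log units; within the scatter), with no clear direction. Compound 4 is estimated at 9000 nM, within a range from 4000 nM to 20000 nM.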

Compound 4, half-maximal inhibitory concentration: 17000 nM
For compound 4 the middle estimate is 1.9-fold (0.28 log units) below the measured one; low and high end bracket the measured number.
By their numbers in this assay, from the lowest: compounds 2, 1, 4 and 3 (each within the scatter of the next, the first and the last beyond it).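

In this assay hydrogen in place of chloro on an aromatic carbon gives a 2.1-fold higher number from compound 2 to compound 4 (0.32 log units; beyond the scatter) as a modest step, the first view of that chlorine on its own. The other new steps, a 1.8-fold higher number from compound 1 to compound 4 (0.25 log units; within the scatter) and a 1.1-fold lower number from compound 3 to compound 4 (0.04 log units; within the scatter) both stay within the scatter, so compound 4 cannot be told apart from compound 1 or compound 3. No measured evidence explains the step from compound 2 to compound 4.

Still open, going by these compounds, is whether fluoro or methoxy in place of the chloro would give a number like that of compound 2. Also open, on these data alone, is how a longer chain carrying the benzamido would read.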